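Urea aryl swap on the dimethylaminoethyl-triazole series

The compounds below may be only part of what the source reports. "The series", "measured", "known", "first", "only" and "open" are said of these compounds alone.

Measured so far:
Compound 1 `Cn1ncnc1-c1cc(Oc2ccc(NC(=O)Nc3cccc(C(F)(F)F)c3)cc2F)ccn1`: 11600 nM
Compound 2 `CN(C)CCn1cnnc1-c1cc(Oc2ccc(NC(=O)Nc3cccc(C(F)(F)F)c3)cc2F)ccn1`: 2150 nM

Within the data shown here, in a functional assay on NCI-H460 cells (Homo sapiens) for antiproliferative activity, read by MTT assay, with a stated time of 72 h (on this read-out lower numbers stand for stronger inhibition and higher numbers for weaker inhibition), compound 2 gives the lowest of the two numbers; the only step recorded, a 5.4-fold lower number from compound 1 to compound 2 (0.73 log units; beyond the scatter), separates it from compound 1. Compound 3 `CN(C)CCn1cnnc1-c1cc(Oc2ccc(NC(=O)Nc3ccc(F)c(F)c3)cc2F)ccn1` differs from compound 2 by 3,4-difluorophenyl in place of 3-(trifluoromethyl)phenyl on an amide-type nitrogen. Among the measured compounds shown here, no measured step touches the urea aryl group, so the single step between compound 1 and compound 2 gives no guide to this change, and any expectation rests on the change itself. A step somewhat beyond the scatter toward a higher number is expected, a 2.3-fold higher number from compound 2 to compound 3 (0.37 log units; beyond the scatter). Compound 3 is therefore estimated at 5000 nM, with a range from 1500 nM to 16000 nM.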

Compound 3, half-maximal inhibitory concentration: 9050 nM
For compound 3 the middle estimate is 1.8-fold (0.26 log units) below the measured one; the measured number falls inside the stated range.
By their numbers in this assay, from the lowest: compound 2; then compounds 3 and 1 (each within the scatter of the next).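

The urea aryl group is a position that responds in this assay: with the 4-(2-(dimethylamino)ethyl)-4H-1,2,4-triazol-3-yl group held fixed, 3,4-difluorophenyl in place of 3-(trifluoromethyl)phenyl on the amide-type nitrogen gives a 4.2-fold higher number from compound 2 to compound 3 (0.62 log units; beyond the scatter). Activity in this series therefore depends on this aryl group as well as on the triazole substituent. No data on hand explain the weakening.

Open, from the compounds shown here alone, is whether the trifluoromethyl group itself or the two fluorines drive the step, which 3-chlorophenyl or 4-fluorophenyl on the same nitrogen could help separate. Also open, going by these compounds, is whether the same swap behaves alike with 1-methyl-1H-1,2,4-triazol-5-yl on the core.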